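Working notes: substituent on the aromatic nitrogen, compound 4

A few compounds are considered here, and "the series" means these few. Any claim that something is new, unique, unknown or untested is made for them only; others in the source may bear on it.

Measured so far in an assay on isolated protein for inhibition of protein deacetylase HDAC6 (Homo sapiens), with a stated time of 60 min; a higher number here means a weaker inhibitor, a lower number a stronger inhibitor:
compound 1 `CS(=O)(=O)c1ccc(-n2ccc3cnc(Nc4cnn(CCCCCCC(=O)NO)c4)nc32)cc1` gives 5.9 nM
compound 2 `O=C(CCCCCCn1cc(Nc2ncc3ccn(Cc4cccc(F)c4)c3n2)cn1)NO` gives 14.7 nM
compound 3 `COc1cccc(Cn2ccc3cnc(Nc4cnn(CCCCCCC(=O)NO)c4)nc32)c1` gives 28.8 nM

Compound 3 holds the highest number of the three, though its gap to compound 2 is within the scatter, as a 2.0-fold higher number from compound 2 to compound 3 (0.29 log units; within the scatter) shows; only its gap to compound 1 is beyond it, seen in a 4.9-fold higher number from compound 1 to compound 3 (0.69 log units; beyond the scatter).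

Compound 4 `O=C(CCCCCCn1cc(Nc2ncc3ccn(C4CCCC4)c3n2)cn1)NO` differs from compound 3 in one place: cyclopentyl in place of 3-methoxybenzyl on an aromatic nitrogen. Among the measured compounds shown here, no measured pair tests a non-aromatic ring at this nitrogen. What bears on it are the two changes at the same nitrogen, a 2.5-fold higher number from compound 1 to compound 2 (0.40 log units; beyond the scatter) and a 4.9-fold higher number from compound 1 to compound 3 (0.69 log units; beyond the scatter), both modest, and the change between the two benzyl groups, a 2.0-fold higher number from compound 2 to compound 3 (0.29 log units; within the scatter), within the scatter. A step of at most modest size in this assay is therefore expected, with no firm direction, and a wide range is kept.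

For compound 4 the expected step is a 1.4-fold higher number from compound 3 to compound 4 (0.14 log units; within the scatter), giving an estimate of 40 nM with a range from 12 nM to 130 nM.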

Compound 4, half-maximal inhibitory concentration: 22 nM
The estimate for compound 4 lay 1.8-fold (0.26 log units) above the measured number; low and high end bracket the measured number.
By their numbers in this assay, from the lowest: compound 1; then compounds 2, 4 and 3 (each within the scatter of the next).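

In this assay, the first non-aromatic ring at this nitrogen gives no step beyond the scatter against either benzyl group, with a 1.3-fold lower number from compound 3 to compound 4 (0.12 log units; within the scatter) and a 1.5-fold higher number from compound 2 to compound 4 (0.18 log units; within the scatter), so among these compounds the benzene ring of the benzyl groups is not required to stay at this level, even with 5 heavy atoms in place of 9. The 4-(methylsulfonyl)phenyl group alone stands apart, and cyclopentyl joins the benzyl groups on the far side of that gap, with a 3.7-fold higher number from compound 1 to compound 4 (0.57 log units; beyond the scatter). Nothing measured here explains this pattern.

The shown compounds cannot separate the contribution of the methylsulfonyl group from that of a phenyl ring attached directly to the nitrogen, since the two always change together. Also open, from the compounds shown here alone, is how a ring bearing an amine, such as piperidine, or a chain ending in a carboxylic acid would fare at this nitrogen.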